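Extending the ethyl chain of compound 1 to butyl

The source may hold more compounds than are shown below. What is called first, only, known or untested is meant among the compounds shown, and "the series" means these compounds.

In a functional assay on M21 cells (Homo sapiens) for antiproliferative activity, read by sulforhodamine B assay, with a stated time of 48 h (a lower number here means a stronger inhibitor, a higher number a weaker inhibitor), compound 1 `CCN1CCN(c2ccc(S(=O)(=O)Oc3cccc(Br)c3)cc2)C1=O` gives 3400 nM. Compound 2 `CCN1CCN(c2ccc(S(=O)(=O)Oc3cccc(I)c3)cc2)C1=O` gives 2200 nM, and a 1.5-fold lower number from compound 1 to compound 2 (0.19 log units; within the scatter) keeps the pair together. Compound 3 `CCN1CCN(c2ccc(S(=O)(=O)Oc3ccc(OC)cc3)cc2)C1=O` gives 26000 nM, well apart from both, with a 7.6-fold higher number from compound 1 to compound 3 (0.88 log units; beyond the scatter) and a 12-fold higher number from compound 2 to compound 3 (1.07 log units; beyond the scatter). Compound 1 thus stands with compound 2 at the lower end of the three numbers.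

Compound 4 `CCCCN1CCN(c2ccc(S(=O)(=O)Oc3cccc(Br)c3)cc2)C1=O` differs from compound 1 by ethyl in place of hydrogen on a saturated chain carbon, two bonds along the chain from an amide-type nitrogen in a ring, so that ethyl becomes butyl. All three measured steps change the phenyl group on the oxygen, and none touches this chain. They therefore give no direct measure for this change, and no step beyond the scatter is expected in this assay, in either direction. The estimated step is a 1.1-fold lower number from compound 1 to compound 4 (0.05 log units; within the scatter). The expected value of compound 4 is 3000 nM, with an estimated range of 1000 nM to 9000 nM.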

Compound 4, half-maximal inhibitory concentration: 35000 nM
The estimate for compound 4 lay 12-fold (1.07 log units) below the measured number; the measured number lies above the stated range.
By their numbers in this assay, from the lowest: compounds 2 and 1 (each within the scatter of the next); then compounds 3 and 4 (each within the scatter of the next).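

In this assay the step of a 10-fold higher number from compound 1 to compound 4 (1.01 log units; beyond the scatter) shows that this chain is not a silent place: turning ethyl into butyl, with ethyl in place of hydrogen on a saturated chain carbon, two bonds along the chain from an amide-type nitrogen in a ring, costs much of the antiproliferative activity. Within the data shown here, the earlier compounds changed only the phenyl group on the oxygen, so this is the first sign that the chain also responds, and that one such extension alone can produce a large step. Nothing measured here gives a reason for this loss.

From the compounds shown here alone, whether the loss already appears with propyl, and how a longer chain such as hexyl or a chain ending in an amine would behave, stays open. Also open, going by these compounds, is whether butyl has the same effect with 3-iodophenyl or 4-methoxyphenyl on the oxygen.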